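A few compounds are considered here, and "the series" means these few. Any claim that something is new, unique, unknown or untested is made for them only; others in the source may bear on it.

Compound 1 `CC(C)(C)c1cc(-c2cc(=O)c3ccc(OCC(=O)N4CCN(Cc5ccccc5)CC4)cc3o2)cc(C(C)(C)C)c1O` and compound 2 `CCN(CC)C(=O)COc1ccc2c(=O)cc(-c3cc(C(C)(C)C)c(O)c(C(C)(C)C)c3)oc2c1` share one core and differ only in the group hanging from the aryl ether. In a functional assay for inhibition (a lower number here means a stronger inhibitor, a higher number a weaker inhibitor), compound 1 gives 3000 nM, and compound 2 gives 3000 nM, so compound 2 stands level with compound 1, the two values lying within the usual scatter of each other. Compound 3 `CN(C)CCCOc1ccc2c(=O)cc(-c3cc(C(C)(C)C)c(O)c(C(C)(C)C)c3)oc2c1` is built from compound 2 by one change: 2-(dimethylamino)ethyl in place of diethylcarbamoyl on a saturated chain carbon bound to an oxygen on an aromatic ring. Among the compounds with values here, no measured pair shows this change, so the expected step is small, no further than the scatter: no change at the digits printed from compound 2 to compound 3 (within the scatter). Compound 3 is therefore estimated at 3000 nM in this assay, within a range from 1000 nM to 10000 nM.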

Compound 3, half-maximal inhibitory concentration: 700 nM
Beside the measured number, compound 3's estimate is 4.3-fold (0.63 log units) above it, and the stated range ends above it.
By their numbers in this assay, from the lowest: compound 3; then compounds 1 and 2 (each within the scatter of the next).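

In this assay, the earlier pair, compound 1 and compound 2, stood level, so changing the group at this position had not yet moved the number. Putting 3-(dimethylamino)propyl in place of (diethylcarbamoyl)methyl gives a 4.3-fold lower number from compound 2 to compound 3 (0.63 log units; beyond the scatter), which shows that the value does respond to what is attached here. No available evidence accounts for this step.

Still open, as far as these compounds go, is whether the amine or the chain drives the step, since a plain propyl chain with no amine would separate the two. A 2-(dimethylamino)ethyl chain on the oxygen would test the chain length.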